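Swapping Chloro for Methyl on a Short-Lived Core

The source may report more compounds than this note shows. Statements on the series, on what has been measured and on what is new or still open speak of the compounds shown alone.

Compound 1 `Cc1cnc(NC(=O)NCCOc2ccc(Cl)c(C)c2)s1`: < 0.0334 h
Compound 2 `Cc1cnc(NC(=O)CCCOc2cccc(Cl)n2)s1`: < 0.0334 h
Compound 3 `O=C(CCCOc1ccccc1)Nc1ncc(Cl)s1`: 0.0333 h

All three were tested in an ADME assay on microsomes from liver (Mus musculus) for metabolic stability, read by LC-MS, using NADPH, tested at 1 uM; on this read-out lower numbers stand for a shorter-lived compound and higher numbers for a longer-lived compound. The result for compound 1 is a limit of the assay, not a number. The result for compound 2 is likewise a limit. Among the compounds with values here, compound 3 is the only one with an actual number, and that number sits at the very edge of the limit of < 0.0334 h in this assay, at which 2 of the 3 values shown sit. Within the data shown here, every compound measured so far is therefore about as short-lived as the assay can register.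

Compound 4 `Cc1cnc(NC(=O)CCCOc2ccccc2)s1` has not yet been measured. It differs from compound 3 in one place: methyl in place of chloro on an aromatic carbon. Among the measured compounds shown here, no two measured compounds differ in a single place, so no measured step guides the size of this change. Since every measured compound sits at the floor of the assay, the step of a 1.0-fold lower number from compound 3 to compound 4 (0.00 log units; within the scatter) is expected to be none beyond the scatter. Compound 4 is estimated at 0.033 h, within 0.02 h to 0.07 h.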

Compound 4, half-life: 0.0333 h
Compound 4: middle estimate off by 1.0-fold (0.00 log units), on the low side, within the range that was stated.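

Within the data shown here, this is the first step between two compounds that differ in one place: methyl in place of chloro on the aromatic carbon next to the ring sulfur gives no change at the digits printed from compound 3 to compound 4 (within the scatter). Little can be read about this position from that step, since both compounds sit at the edge of what this assay can register: the limit of < 0.0334 h in this assay, at which 2 of the 4 values shown sit.

A real difference between chloro and methyl could stay hidden there. Still open, going by these compounds, is whether an amine or a methoxy group at this position, or a longer chain elsewhere on compound 4, would give a half-life clear of that limit.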